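A side-chain swap in a weakly active series

A few compounds are considered here, and "the series" means these few. Any claim that something is new, unique, unknown or untested is made for them only; others in the source may bear on it.

Measured in a functional assay on HCT-116 cells (Homo sapiens) for antiproliferative activity, read by sulforhodamine B assay, with a stated time of 72 h; a higher number here means a weaker inhibitor, a lower number a stronger inhibitor:
Compound 1 `Cn1cc(-c2ccc(=O)n(CCOc3ccnc4cc(OCCCCCCC(=O)NO)ccc34)n2)cn1`: > 10000 nM, a limit
Compound 2 `Cn1cc(-c2ccc(=O)n(CCOc3ccnc4cc(OCCCCCC(=O)Nc5ccccc5N)ccc34)n2)cn1`: 7000 nM
Compound 3 `Cn1cc(-c2ccc(=O)n(CCOc3ccnc4cc(OCc5ccc(CCC(=O)Nc6ccccc6N)cc5)ccc34)n2)cn1`: > 10000 nM, a limit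

Compound 1 gives only a limit, > 10000 nM, and so stands at the limit of > 10000 nM in this assay, at which 2 of the 3 values shown sit.

Compound 4 `Cn1cc(-c2ccc(=O)n(CCOc3ccnc4cc(C(=O)Nc5ccccc5N)ccc34)n2)cn1` keeps the shared core of compound 1 but changes one group: (2-aminophenyl)carbamoyl in place of (6-(hydroxycarbamoyl)hexyl)oxy on an aromatic carbon. The (6-(hydroxycarbamoyl)hexyl)oxy chain is gone, and the (2-aminophenyl)carbamoyl sits on the aromatic carbon itself.

Within the data shown here, the only measured step that bears on this is an at least 1.4-fold lower number from compound 1 to compound 2 (0.15 log units; that floor lies within the scatter). There, the same (2-aminophenyl)carbamoyl group arrives on a chain. It suggests little movement in this assay, at most slightly towards a lower number.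

The expected change is an at least 1.2-fold lower number from compound 1 to compound 4 (0.09 log units; that floor lies within the scatter). For compound 4 the estimate is 8000 nM, with an expected range from 3000 nM to 20000 nM.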

Compound 4, half-maximal inhibitory concentration: > 10000 nM
Compound 4: only a limit was reported; the forecaster's own chance of this, stated with the estimate: 55%; middle value at least 1.2-fold (0.09 log units) from the limit.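

Compound 4 gives [ > 10000 nM ] in this assay, which is a limit; compound 1 also has only a limit, and the step between them cannot be read. Whether either compound has any measurable activity here stays open: the limit of > 10000 nM in this assay, at which 3 of the 4 values shown sit.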